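Dithiocarbamate amine variation on a benzamide core

The source may hold more compounds than are shown below. What is called first, only, known or untested is meant among the compounds shown, and "the series" means these compounds.

Measured compounds:
compound 1 `Nc1ccccc1NC(=O)c1ccc(CSC(=S)N2CCN(c3ccccc3)CC2)cc1` — 87.4%
compound 2 `CN(C(=S)SCc1ccc(C(=O)Nc2ccccc2N)cc1)c1cccnc1` — 82.5%
compound 3 `Nc1ccccc1NC(=O)c1ccc(CSC(=S)N(Cc2ccccc2)Cc2ccccc2)cc1` — 30.7%

In a functional assay on MGC-803 cells (Homo sapiens) for antiproliferative activity, read by CCK-8 assay, with a stated time of 72 h, tested at 8 uM (on this read-out higher numbers stand for a stronger effect at the one concentration tested and lower numbers for a weaker effect), compound 2 gives 82.5%. Its number lies close to that of compound 1, which gives 87.4%, the gap between them falling within the scatter. Compound 3, which gives 30.7%, sits far below compound 2, that gap lying beyond the scatter. The three share one core and differ only in the amine attached to the thiocarbonyl carbon.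

Compound 4 `Nc1ccccc1NC(=O)c1ccc(CSC(=S)N2CCCC2)cc1` has not yet been measured in this assay. It carries the change (pyrrolidin-1-yl in place of methyl(pyridin-3-yl)amino on a thiocarbonyl carbon). Among the compounds with values here, no measured pair shows this change directly, so its effect is open. Compound 1 and compound 2 show that two different cyclic or aryl-bearing amines give similar high numbers, while compound 3 shows that a third amine gives a much lower one, so either outcome is possible. A decline from compound 2 is expected, with a number 20.5 percentage points lower from compound 2 to compound 4 (beyond the scatter) judged as the estimated step. Compound 4 is therefore expected to give about 62%, in a range from 30% to 88%.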

Compound 4, a percentage reported as inhibition, at one concentration (the size of the read-out at that concentration, not a potency): 83.4%
Beside the measured number, compound 4's estimate is 21.4 percentage points below it; low and high end bracket the measured number.
By their numbers in this assay, from the lowest: compound 3; then compounds 2, 4 and 1 (each within the scatter of the next).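

In this assay, pyrrolidin-1-yl in place of methyl(pyridin-3-yl)amino on a thiocarbonyl carbon gives a number 0.9 percentage points higher from compound 2 to compound 4 (within the scatter), so the read-out holds through this change. The position therefore keeps a high number without an aromatic ring or a second nitrogen in the amine: a five-membered non-aromatic ring serves as well as the six-membered aromatic ring of compound 2, and compound 3 remains the only one of the amines shown to fall away. No measurement is at hand that explains why this change leaves the number in place.

On these data alone, it remains open whether an open-chain amine such as diethylamino, or a morpholine ring, would hold the number as well. Also open, as far as these compounds go, is which feature of the amine in compound 3 goes with its value of 30.7%.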